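The source may hold more compounds than are shown below. What is called first, only, known or untested is meant among the compounds shown, and "the series" means these compounds.

Measured compounds:

- compound 1, `O=C(NS(=O)(=O)c1ccc(F)cc1)c1ccc(Nc2nc(NC3(c4ccc(Cl)cc4)CC3)nc(OCC(F)(F)F)n2)cc1`: 99%
- compound 2, `CC(=O)NCCS(=O)(=O)NC(=O)c1ccc(Nc2nc(NC3(c4ccc(Cl)cc4)CC3)nc(OCC(F)(F)F)n2)cc1`: 100%
- compound 3, `O=C(NS(=O)(=O)CCNCc1ccccc1)c1ccc(Nc2nc(NC3(c4ccc(Cl)cc4)CC3)nc(OCC(F)(F)F)n2)cc1`: 100%

In an ADME assay on microsomes from liver (Rattus norvegicus) for metabolic stability, with a stated time of 10 min (a lower number here means that less of the compound is left, a higher number that more of the compound is left), compound 1 gives 99%, compound 2 gives 100% and compound 3 gives 100%. Compound 3 is level with compound 2 at the digits shown, and the remaining step is a number 1 percentage points higher from compound 1 to compound 3 (within the scatter), so all three numbers sit within the usual scatter of one another; none can be called more stable than the others.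

Compound 4, `CN(C)S(=O)(=O)NC(=O)c1ccc(Nc2nc(NC3(c4ccc(Cl)cc4)CC3)nc(OCC(F)(F)F)n2)cc1`, is the next step: dimethylamino in place of 2-(benzylamino)ethyl on a sulfonyl sulfur. Two measured steps changed the same group on the sulfonyl sulfur: a number 1 percentage points higher from compound 1 to compound 2 (within the scatter) and a number 1 percentage points higher from compound 1 to compound 3 (within the scatter). A third step, no change at the digits printed from compound 2 to compound 3 (within the scatter), swapped a group within that side chain. None moved the number beyond the scatter, even though those groups differed widely in size and make-up. Dimethylamino is smaller again, but nothing measured here suggests size at this position matters.

The expected step in this assay is therefore a number 2 percentage points lower from compound 3 to compound 4 (within the scatter), which means no change beyond the scatter. Compound 4 is estimated to give 98%, with a likely range from 88% to 100%.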

Compound 4, percent of the compound remaining: 76%
The estimate for compound 4 lay 22 percentage points above the measured number, and the stated range ends above it.
By their numbers in this assay, from the lowest: compound 4; then compounds 1, 2 and 3 (each within the scatter of the next).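

Going by these compounds alone, the group on the sulfonyl sulfur can matter after all: in this assay dimethylamino brings a number 24 percentage points lower from compound 3 to compound 4 (beyond the scatter) and a number 24 percentage points lower from compound 2 to compound 4 (beyond the scatter) and also a number 23 percentage points lower from compound 1 to compound 4 (beyond the scatter) and so gives the first change beyond the scatter at this place. The three earlier groups, 4-fluorophenyl, 2-acetamidoethyl and 2-(benzylamino)ethyl, could look alike only until this fourth group showed that the place is not indifferent to what sits there. Nothing available here explains the drop.

Dimethylamino differs from the other three groups in more than one way, as it joins the sulfonyl sulfur through nitrogen and lacks their longer side chains, so the feature behind the drop stays open. A plain ethyl group or a diethylamino group on the sulfur would help to separate these two features.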